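Pyridyl-to-thienyl swap at the aryl position beside the ring nitrogen

The source may hold more compounds than are shown below. What is called first, only, known or untested is meant among the compounds shown, and "the series" means these compounds.

Measured compounds:
compound 1 `Oc1ccc(-c2cc(-c3ccccn3)nc(-c3ccccc3Cl)c2)cc1`: "not determined" (no result reported)
compound 2 `Oc1ccc(-c2cc(-c3cccc(Cl)c3)nc(-c3ccccn3)c2)cc1`: 27900 nM

Within the data shown here, in a functional assay on T47D cells (Homo sapiens) for cytotoxicity, read by CCK-8 assay and cell counting, with a stated time of 2 days (a higher number here means a weaker inhibitor, a lower number a stronger inhibitor), compound 2 gives 27900 nM, the only number in hand, and compound 1 gives "not determined" (no result reported), adding no figure. Compound 3 `Oc1ccc(-c2cc(-c3cccc(Cl)c3)nc(-c3cccs3)c2)cc1` carries thiophen-2-yl in place of pyridin-2-yl on an aromatic carbon. Among the measured compounds shown here, no measured step covers such an exchange, so the expectation rests on compound 2 alone. In this assay the move is expected to stay within the scatter, with no clear direction, so the step from compound 2 to compound 3 is estimated at a 1.1-fold lower number from compound 2 to compound 3 (0.05 log units; within the scatter). Compound 3 is accordingly expected near 25000 nM, between 8000 nM and 80000 nM.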

Compound 3, half-maximal inhibitory concentration: 5350 nM
Compound 3: the middle estimate sits 4.7-fold (0.67 log units) above what was measured, outside the stated range (below it).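

In this assay, thiophen-2-yl in place of pyridin-2-yl on an aromatic carbon next to the ring nitrogen gives a 5.2-fold lower number from compound 2 to compound 3 (0.72 log units; beyond the scatter). This position is therefore not indifferent to the aromatic ring it carries, and the read-out responds to this single exchange with the 3-chlorophenyl and 4-hydroxyphenyl groups unchanged. No measurement at hand accounts for the step.

From the compounds shown here alone, whether the step follows the sulfur atom or the five-membered ring remains open. A furan-2-yl or plain phenyl group at this position would help separate the two.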